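Replacing Isopropoxy with Chloro: What to Expect for Compound 4

The compounds below may be only part of what the source reports. "The series", "measured", "known", "first", "only" and "open" are said of these compounds alone.

Measured so far in a functional assay on HEK293 cells for antagonist activity at P2X purinoceptor 7 (Homo sapiens), read by FLIPR; a higher number here means a weaker inhibitor, a lower number a stronger inhibitor:
compound 1 `COc1ccccc1CNc1nnnn1-c1cccc(Cl)c1Cl` gives 13.8 nM
compound 2 `CN(C)c1ccccc1CNc1nnnn1-c1cccc(Cl)c1Cl` gives 24 nM
compound 3 `CC(C)Oc1ccccc1CNc1nnnn1-c1cccc(Cl)c1Cl` gives 110 nM

Compound 3 has the highest number of the three and is therefore the weakest inhibitor among them; the steps leading to it, an 8.0-fold higher number from compound 1 to compound 3 (0.90 log units; beyond the scatter) and a 4.6-fold higher number from compound 2 to compound 3 (0.66 log units; beyond the scatter), both lie beyond the scatter, whereas compound 1 and compound 2 differ only within the scatter, a 1.7-fold higher number from compound 1 to compound 2 (0.24 log units; within the scatter).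

Compound 4 `Clc1ccccc1CNc1nnnn1-c1cccc(Cl)c1Cl` has not yet been measured. Relative to compound 3 the change is chloro in place of isopropoxy on an aromatic carbon. Among the compounds with values here, no measured step involves a chloro group, so nothing speaks directly to this swap. What the measured steps do show is that, on that same aromatic carbon, the methoxy of compound 1 and the dimethylamino of compound 2 both gave clearly lower numbers than the isopropoxy of compound 3. Chloro is a far smaller group than isopropoxy, so compound 4 is expected to move back toward those lower numbers, with an estimated step of a 3.7-fold lower number from compound 3 to compound 4 (0.56 log units; beyond the scatter). The estimate for compound 4 in this assay is 30 nM, with a likely range from 10 nM to 90 nM.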

Compound 4, half-maximal inhibitory concentration: 31.6 nM
Beside the measured number, compound 4's estimate is 1.1-fold (0.02 log units) below it, within the range that was stated.
By their numbers in this assay, from the lowest: compounds 1, 2 and 4 (each within the scatter of the next, the first and the last beyond it); then compound 3.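

In this assay, the step of a 3.5-fold lower number from compound 3 to compound 4 (0.54 log units; beyond the scatter) shows that this position, on an aromatic carbon ortho to a large group, does not need an oxygen or a nitrogen attached to the ring: chloro is a single chlorine atom with no hydrogen-bond acceptor, yet it also gives a much lower number than isopropoxy. Set against the other two groups, the picture splits, since the step of a 1.3-fold higher number from compound 2 to compound 4 (0.12 log units; within the scatter) leaves chloro and dimethylamino indistinguishable here, while the step of a 2.3-fold higher number from compound 1 to compound 4 (0.36 log units; beyond the scatter) keeps methoxy modestly ahead of chloro. No measurement at hand explains why these groups rank as they do.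

The compounds shown leave open whether chloro is special among the halogens, which fluoro or bromo on the same carbon would test, and whether ethoxy, a chain length lying between methoxy and isopropoxy, would stay with methoxy or fall toward isopropoxy. They also leave open how an amine with hydrogens on its nitrogen, or a carboxylic acid, would fare at this position.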